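Bromoethenyl in Place of Methyl: An Expected Step

This account rests on a few compounds, and the source may have more. Where it says the series, first, only, none or still open, it means among the compounds named here.

Compound 1 has the structure `Cc1cn(COCCO)c(=O)[nH]c1=O`. In a functional assay on L1210 cells (Mus musculus) for inhibition (a higher number here means a weaker inhibitor, a lower number a stronger inhibitor), compound 1 gives > 1000 ug/mL, which is a limit of the assay and not a number. This is the limit of > 1000 ug/mL in this assay, at which 1 of the 2 values shown sits. Among the compounds with values here, compound 2, with the structure `Nc1ccn(COCCO)c(=O)n1`, is the only other measured compound here; in this assay compound 2 gives 675 ug/mL. Compound 3, with the structure `O=c1[nH]c(=O)n(COCCO)cc1/C=C/Br`, has not yet been measured. It differs from compound 1 in a single place: 2-bromoethenyl in place of methyl on an aromatic carbon. Within the data shown here, no step between two measured compounds that differ in one place is known, and the two measured values share no such pair, so the size of the change on going to compound 3 rests on expectation alone. The step of a number no higher from compound 1 to compound 3 (the limit leaves the size open) is expected to be none beyond the scatter. Compound 3 is expected to give 1000 ug/mL, with a likely range from 300 ug/mL to 3000 ug/mL.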

Compound 3, concentration for 50% inhibition: > 1000 ug/mL
Compound 3 gave a limit, no number; the forecaster's own chance of this, stated with the estimate: 70%; the middle value lies on the limit itself.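

Compound 1 and compound 3 both give a limit of the assay and not a number in this assay, so no step can be read between them: the limit of > 1000 ug/mL in this assay, at which 2 of the 3 values shown sit.

The compounds shown leave open whether 2-bromoethenyl in place of methyl changes inhibition at all, and by how much.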